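One added methyl on a tightly bound compound

The source may report more compounds than this note shows. Statements on the series, on what has been measured and on what is new or still open speak of the compounds shown alone.

In an ADME assay on a cell-free system (plasma, Homo sapiens) for protein binding, compound 1 `Cc1cn2cc(-c3cc4ccc(N5CCN(C)CC5)cc4c(=O)o3)nc2c(C)n1` gives 93% while compound 2 `Cc1cn2cc(-c3cc4ccc(N5CCN(C)CC5)cc4oc3=O)nc2cn1` gives 97% and compound 3 `Cc1cn2nc(-c3cc(=O)n4cc(N5CCN(C)CC5)ccc4n3)cc2c(C)n1` gives 80% as its reading. Percentages this close to the top of the scale are easier to compare through the share left unbound. Compound 2 has the smallest free share of the three, and its gaps to compound 1 and to compound 3 both lie beyond the usual scatter.

The next compound to follow is compound 4 `Cc1cn2cc(-c3cc4ccc(N5CCN(C)CC5)cc4oc3=O)nc2c(C)n1` which differs from compound 2 in one place only. The change is methyl in place of hydrogen on an aromatic carbon and in words it is methyl in place of hydrogen on an aromatic carbon.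

Among the compounds with values here, no two measured compounds differ in just one place, so the data hold no direct example of this change. The three values alone cannot give its size. A small step is expected, leaning towards more binding, and it is not expected to go beyond the scatter. The estimate is a 1.2-fold lower unbound fraction from compound 2 to compound 4 (0.08 log units; within the scatter) as the expected shift. For compound 4 the estimated value is 97.5% with an expected range from 94% to 99.3% for the measurement still to come.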

Compound 4, plasma protein binding: 97%
Compound 4: the middle estimate sits 1.2-fold (0.08 log units) (unbound fraction) below what was measured, and the stated range covers the measured number.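

In this assay, putting methyl in place of hydrogen on an aromatic carbon, next to the ring nitrogen, gives no change at the digits printed from compound 2 to compound 4 (within the scatter), the first direct reading of this change among these compounds. This position on the six-membered aromatic ring with 2 nitrogen therefore takes the added methyl without a visible shift in the reading, although whole-number values this close to the top of the scale could hide a small shift in the unbound share. Nothing measured here explains the result.

This is a single pair on a single core, so it remains open whether methyl would behave the same way on the other cores shown, where binding is less tight. From the compounds shown here alone, it also remains open whether a longer chain such as ethyl, an amine or a carboxylic acid on the same carbon would leave the reading just as steady, or would instead change how much of the compound stays free.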